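Swapping the Acetyl Cap on a Piperidine Nitrogen

The compounds below may be only part of what the source reports. "The series", "measured", "known", "first", "only" and "open" are said of these compounds alone.

Compound 1 `CC(=O)N1CCC(Sc2c[nH]c3ccc(Br)cc23)CC1`: 2.8 mg/kg
Compound 2 `Cc1[nH]c2ccc(F)cc2c1SC1CCNCC1`: 12.7 mg/kg
Compound 3 `CN1CCC(Sc2cn(C)c3ccc(Cl)cc23)CC1`: 9.3 mg/kg

Three compounds share a core in which a six-membered ring amine is joined through sulfur to an indole-type bicycle, and all three have been tested in a functional assay on the whole organism with Mus musculus as the target, in the hot plate test; a lower number here means that less compound is needed, a higher number that more compound is needed for the effect. Compound 1 needs the lowest dose of the three, 2.8 mg/kg. Compound 3 requires 9.3 mg/kg, and compound 2 requires 12.7 mg/kg; both of those gaps to compound 1 lie beyond the usual scatter, though each of these compounds differs from compound 1 in more than one place, so no single change can be read from them.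

Compound 4 `CON1CCC(Sc2c[nH]c3ccc(Br)cc23)CC1` is compound 1 with methoxy in place of acetyl on an amine nitrogen in a ring. Nothing measured here isolates the effect of replacing this cap; the two compounds that carry a different group on that nitrogen also differ elsewhere and sit at higher doses. A modest rise in dose, or no change beyond the scatter, is the most plausible expectation, and the estimated step of a 1.6-fold higher number from compound 1 to compound 4 (0.21 log units; within the scatter) reflects that. Compound 4 is therefore expected to give about 4.5 mg/kg, within a range of 1.5 mg/kg to 14 mg/kg.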

Compound 4, dose for half-maximal effect: 3.2 mg/kg
For compound 4 the middle estimate is 1.4-fold (0.15 log units) above the measured one; measured number inside the range.
By their numbers in this assay, from the lowest: compounds 1 and 4 (each within the scatter of the next); then compounds 3 and 2 (each within the scatter of the next).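

Among the compounds shown here, with the rest of compound 1 held fixed, this pair gives the first clean reading at this position: in this assay, methoxy in place of acetyl on the amine nitrogen in the ring gives a 1.1-fold higher number from compound 1 to compound 4 (0.06 log units; within the scatter). The acetyl group, with its double bond outside aromatic rings and one more heavy atom, can therefore be exchanged for methoxy here without separating the two compounds in this test. No accompanying measurement offers an explanation for this outcome.

Going by these compounds, whether other groups on this nitrogen would also leave the dose within the scatter remains open, for example a benzyl group, a longer chain or a carboxylic acid. Compound 2 and compound 3 differ from compound 1 in more than one place, so neither shows what a different group on this nitrogen does by itself.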